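Bromine on the outer ring: two cores compared

The source may hold more compounds than are shown below. What is called first, only, known or untested is meant among the compounds shown, and "the series" means these compounds.

Measured so far:
compound 1 `O=C(CSC(=S)N[C@H]1CCOC1=O)Nc1ccc(Br)cc1`, 42800 nM
compound 2 `O=C(CSC(=S)N[C@H]1CCOC1=O)Nc1ccccc1`, 39700 nM
compound 3 `O=C(CCl)Nc1ccc(C(=O)/C=C/c2ccccc2)cc1`, 6940 nM

All three were tested in a functional assay on MGC-803 cells (Homo sapiens) for cytotoxicity, read by MTT assay, with a stated time of 72 h; on this read-out lower numbers stand for stronger inhibition and higher numbers for weaker inhibition. Compound 3 gives the lowest number of the three; its nearest neighbour is compound 2, and the difference between the core of compound 3 and the core of compound 2 is not broken down here.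

From compound 2 to compound 1 the change is bromo in place of hydrogen on an aromatic carbon, and the step it made is a 1.1-fold higher number from compound 2 to compound 1 (0.03 log units; within the scatter). The unmeasured compound 4 `O=C(CCl)Nc1ccc(C(=O)/C=C/c2ccc(Br)cc2)cc1` arises from compound 3 by the same change, (bromo in place of hydrogen on an aromatic carbon), at a place described in the same words.

Because a 1.1-fold higher number from compound 2 to compound 1 (0.03 log units; within the scatter) stayed within the scatter, a step of similar size, a 1.1-fold higher number from compound 3 to compound 4 (0.03 log units; within the scatter), is expected for compound 4. Compound 4 is therefore estimated at 7500 nM, with a likely range from 3000 nM to 18000 nM.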

Compound 4, half-maximal inhibitory concentration: 6050 nM
Beside the measured number, compound 4's estimate is 1.2-fold (0.09 log units) above it, and the stated range covers the measured number.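

The change from hydrogen to bromo, which turns phenyl into 4-bromophenyl, gave a 1.1-fold lower number from compound 3 to compound 4 (0.06 log units; within the scatter) in this assay, so it made no visible difference on this core. The same change behaved alike on the two cores: the same change on two cores in this assay, a 1.1-fold higher number (0.03 log units; within the scatter) from compound 2 to compound 1 and a 1.1-fold lower number (0.06 log units; within the scatter) from compound 3 to compound 4, 1.2-fold (0.09 log units) apart, within the scatter of two such steps

This shows that a step lost in the scatter on one core stayed lost in the scatter on the other, but it covers only these two cores and this one group, and such small steps cannot reveal any finer difference between the cores.

From the compounds shown here alone, whether a different group at the same place, such as an amine or a carboxylic acid, would shift the number on either core remains open. So does whether those shifts would match from one core to the other.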